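The source may hold more compounds than are shown below. What is called first, only, known or untested is meant among the compounds shown, and "the series" means these compounds.

Working notes on the series: in a functional assay on MCF7 cells (Homo sapiens) for antiproliferative activity, read by MTT assay, with a stated time of 24 h (on this read-out higher numbers stand for weaker inhibition and lower numbers for stronger inhibition), compound 1 `Cc1ccc(-c2nn(-c3ccccc3)cc2-c2nc3ccccc3n2S(=O)(=O)c2ccccc2)cc1` gives 830 nM and compound 2 `COc1ccc(S(=O)(=O)n2c(-c3cn(-c4ccccc4)nc3-c3ccc(F)cc3)nc3ccccc32)cc1` gives 530 nM, two numbers within the usual scatter of each other. Compound 3 `O=S(=O)(c1ccc(C(F)(F)F)cc1)n1c(-c2cn(-c3ccccc3)nc2-c2ccc(F)cc2)nc2ccccc21` departs from compound 2 in one place: trifluoromethyl in place of methoxy on an aromatic carbon, para to a large group. Among the compounds with values here, no measured pair shows this change, so nothing yet indicates a direction. The expected move, a 1.1-fold lower number from compound 2 to compound 3 (0.03 log units; within the scatter), is estimated to stay within the scatter. In this assay the estimate for compound 3 is 500 nM, with an expected range of 200 nM to 1300 nM.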

Compound 3, half-maximal inhibitory concentration: 1580 nM
For compound 3 the middle estimate is 3.2-fold (0.50 log units) below the measured one; the whole stated range lies below it.
By their numbers in this assay, from the lowest: compounds 2, 1 and 3 (each within the scatter of the next, the first and the last beyond it).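

In this assay, trifluoromethyl in place of methoxy on an aromatic carbon, para to a large group, gives a 3.0-fold higher number from compound 2 to compound 3 (0.47 log units; beyond the scatter). Within the data shown here, this is the first single-place step, and it shows that the change at this position can move the number beyond the scatter. Nothing at hand accounts for the move.

Among these compounds, whether the step reflects the loss of methoxy or the entry of trifluoromethyl stays open, since this is the only reading of the change. On these data alone, how an amine or a carboxylic acid at this position would read also stays open.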